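The source may report more compounds than this note shows. Statements on the series, on what has been measured and on what is new or still open speak of the compounds shown alone.

In a functional assay on MCF7 cells (Homo sapiens) for antiproliferative activity, read by MTT assay, with a stated time of 48 h (on this read-out higher numbers stand for weaker inhibition and lower numbers for stronger inhibition), compound 3 (`O=C(NS(=O)(=O)c1ccccc1)c1cccnc1Cl`) gives 14000 nM. It sits level with compound 1 (`O=C(NS(=O)(=O)c1ccccc1)c1cccnc1`), which gives 14400 nM, and far from compound 2 (`O=C(NS(=O)(=O)c1ccc(Cl)cc1)c1cncc(Br)c1`), which gives 70 nM.

The next structure is compound 4 (`O=C(NS(=O)(=O)c1ccc(F)cc1)c1cccnc1Cl`), with the change fluoro in place of hydrogen on an aromatic carbon, on a six-membered aromatic ring of carbon only, para to a large group.

Among the measured compounds shown here, only one measured single-place step bears on this, and only loosely. It is a 1.0-fold lower number from compound 1 to compound 3 (0.01 log units; within the scatter), within the scatter, and it is a chloro in place of hydrogen at a different place from the new fluoro. Taken alone, it offers no support for a large change from a halogen swap.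

Compound 2, at 70 nM, carries a chloro and a bromo group and differs from compound 1 in more than one place. The data therefore do not separate what each place contributes, but compound 2 leaves room for a move towards lower numbers.

A modest step is expected, slightly beyond the scatter, with a 2.8-fold lower number from compound 3 to compound 4 (0.45 log units; beyond the scatter) as the estimated change. For compound 4 the estimated value is 5000 nM, with an expected range from 800 nM to 16000 nM.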

Compound 4, half-maximal inhibitory concentration: 12500 nM
For compound 4 the middle estimate is 2.5-fold (0.40 log units) below the measured one; the measured number falls inside the stated range.
By their numbers in this assay, from the lowest: compound 2; then compounds 4, 3 and 1 (each within the scatter of the next).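

Working notes on the series: in this assay, fluoro in place of hydrogen on an aromatic carbon of a six-membered aromatic ring of carbon only, para to a large group, gives a 1.1-fold lower number from compound 3 to compound 4 (0.05 log units; within the scatter), so this single change at this position leaves the number inside the scatter. Together with a 1.0-fold lower number from compound 1 to compound 3 (0.01 log units; within the scatter), a chloro step at a different place, this makes two single-place halogen steps in the series, neither of which can be told from the scatter; compound 2 stands outside this reading, as it differs from the others in more than one place. No data are available that bear on the reason for this result.

Going by these compounds, whether this position responds to any group other than fluoro remains open, for instance an amine, a methoxy group or a carboxylic acid in the same place. Among the compounds shown here, also open is how much each of the several differences in compound 2 contributes to its 70 nM, since no single-place step yet connects it to the rest of the series.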